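Cyclopropyl in Place of Furanyl on a Weak Binder

The source may hold more compounds than are shown below. What is called first, only, known or untested is meant among the compounds shown, and "the series" means these compounds.

Measured so far in an assay on CHO cells for displacement of a labelled ligand from adenosine receptor A1 (Homo sapiens), read by fluorescence, with a stated time of 1 h; on this read-out lower numbers stand for stronger inhibition and higher numbers for weaker inhibition:
compound 1 `CCc1cc2c(=O)[nH]c(-c3ccoc3)nc2s1` gives 56200 nM
compound 2 `O=C(Nc1nc(C2CC2)cs1)c1ccoc1` gives 2950 nM

Within the data shown here, compound 1 stands at the highest of the two numbers; compound 2 sits at a lower number beyond the scatter, yet the two differ in more than one place, so no single step links them. Compound 3 `CCc1cc2c(=O)[nH]c(C3CC3)nc2s1` differs from compound 1 by cyclopropyl in place of furan-3-yl on an aromatic carbon. Among the measured compounds shown here, no measured step of this kind exists here, so the expected step of a 1.1-fold higher number from compound 1 to compound 3 (0.03 log units; within the scatter) is small and without a clear direction. Compound 3 is therefore estimated at 60000 nM, with a range from 12000 nM to 300000 nM.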

Compound 3, inhibition constant: 61700 nM
Compound 3: the middle estimate sits 1.0-fold (0.01 log units) below what was measured; low and high end bracket the measured number.
By their numbers in this assay, from the lowest: compound 2; then compounds 1 and 3 (each within the scatter of the next).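

In this assay, cyclopropyl in place of furan-3-yl on the aromatic carbon between two ring nitrogen atoms gives a 1.1-fold higher number from compound 1 to compound 3 (0.04 log units; within the scatter) and so makes no difference beyond the scatter. At this position of the shared core, then, a five-membered aromatic ring with an oxygen and a three-membered carbon ring read alike. No measurement available explains this similarity. Going by these compounds, only these two groups are compared at this position, so it remains open whether an amine, a carboxylic acid or a longer alkyl chain there would shift the number beyond the scatter.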